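The source may report more compounds than this note shows. Statements on the series, on what has been measured and on what is new or still open speak of the compounds shown alone.

Among the three compounds measured so far, compound 3, with the structure `Cc1nc2c3ccccc3ccc2c2nc3c(ccc4ccccc43)c(-c3ccccc3N)c12`, stands second highest in a functional assay on HeLa cells (Homo sapiens) for cytotoxicity, read by MTT assay, with a stated time of 48 h (a lower number here means a stronger inhibitor, a higher number a weaker inhibitor), where compound 3 gives 16200 nM. Compound 1, of structure `Cc1nc2c3ccccc3ccc2c2nc3c(ccc4ccccc43)c(-c3cccnc3)c12`, gives 3860 nM in this assay, and compound 2, of structure `COc1ccc(-c2c3ccc4ccccc4c3nc3c2c(C)nc2c4ccccc4ccc32)cc1`, gives 45900 nM in this assay. The step to compound 4, of structure `Cc1nc2c3ccccc3ccc2c2nc3c(ccc4ccccc43)c(-c3ccc(O)cc3)c12`, is 4-hydroxyphenyl in place of 2-aminophenyl on an aromatic carbon. Of the measured steps, the one nearest in kind is a 2.8-fold lower number from compound 2 to compound 3 (0.45 log units; beyond the scatter), since compound 2 also carries a ring substituted at the same position of its pendant phenyl as compound 4 does; the change a 4.2-fold higher number from compound 1 to compound 3 (0.62 log units; beyond the scatter) bears on it only indirectly. On this basis a modest rise back toward the number of compound 2 is expected, though a hydroxy group is not a methoxy group and the step may well stay small. Compound 4 is therefore estimated at 25000 nM in this assay, with a range from 8000 nM to 80000 nM, which amounts to an expected 1.5-fold higher number from compound 3 to compound 4 (0.19 log units; within the scatter).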

Compound 4, half-maximal inhibitory concentration: 4630 nM
Compound 4: middle estimate off by 5.4-fold (0.73 log units), on the high side; the whole stated range lies above it.
By their numbers in this assay, from the lowest: compounds 1 and 4 (each within the scatter of the next); then compound 3; then compound 2.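

Removing the methyl from the oxygen of compound 2 is the sharpest contrast yet at this position: in this assay, hydrogen in place of methyl gives a 9.9-fold lower number from compound 2 to compound 4 (1.00 log units; beyond the scatter), so a small change on the pendant ring's oxygen alone moves the number strongly. The 4-hydroxyphenyl group also gives a 3.5-fold lower number from compound 3 to compound 4 (0.54 log units; beyond the scatter) against 2-aminophenyl, while against pyridin-3-yl it gives a 1.2-fold higher number from compound 1 to compound 4 (0.08 log units; within the scatter), so this position can carry either of these two different rings with no readable difference. No measurement here offers an explanation for these steps.

Since 2-aminophenyl and 4-hydroxyphenyl differ both in the group and in where it sits on the ring, the compounds shown do not separate those two changes. As far as these compounds go, it also remains open how an amine in place of the hydroxy group, a carboxylic acid, or a longer chain on that oxygen would read.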